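This account rests on a few compounds, and the source may have more. Where it says the series, first, only, none or still open, it means among the compounds named here.

Of the compounds shown here, three have been measured in a functional assay on MCF7 cells (Homo sapiens) for cytotoxicity, read by MTT assay, with a stated time of 24 h; a lower number here means a stronger inhibitor, a higher number a weaker inhibitor. Compound 1 `COc1ccc(/C=C2\CN(C(=S)SCc3cn(Cc4ccccc4Cl)nn3)C/C(=C\c3ccc(OC)cc3)C2=O)cc1` gives only a limit, > 100000 nM, which is the limit of > 100000 nM in this assay, at which 1 of the 3 values shown sits. Compound 2 `O=C1/C(=C/c2ccccc2F)CN(C(=S)SCc2cn(Cc3ccccc3Cl)nn2)C/C1=C\c1ccccc1F` gives 78700 nM in this assay. Compound 3 `COc1ccc(/C=C2\CN(Cc3cn(Cc4cccc(Cl)c4)nn3)C/C(=C\c3ccc(OC)cc3)C2=O)cc1` gives 99000 nM in this assay, the highest of the two numbers, though its gap to compound 2 lies within the scatter, so the two cannot be told apart. Compound 4 `COc1ccc(/C=C2\CN(Cc3cn(Cc4ccccc4Cl)nn3)C/C(=C\c3ccc(OC)cc3)C2=O)cc1` is built from the same atoms as compound 3, joined differently: 2-chlorophenyl in place of 3-chlorophenyl on a saturated chain carbon bound to an aromatic nitrogen. Within the data shown here, no measured pair shows this same change, so the step is estimated from the neighbouring values alone; the expected step from compound 3 to compound 4 is a 1.0-fold higher number from compound 3 to compound 4 (0.00 log units; within the scatter), no more than the scatter in either direction. Compound 4 is therefore expected to give about 100000 nM in this assay, between 40000 nM and 250000 nM.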

Compound 4, half-maximal inhibitory concentration: > 100000 nM
Compound 4: a limit, no number (the forecaster's own chance of this, stated with the estimate: 45%); the middle value lies on the limit itself.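

Compound 4 gives only a limit, > 100000 nM, not a number. The change of 3-chlorophenyl to 2-chlorophenyl on a saturated chain carbon bound to an aromatic nitrogen gives a number no lower from compound 3 to compound 4 (the limit leaves the size open), so this swap brings no measurable gain in this assay. How much the swap matters at this position cannot be read, because the values crowd at the top of the measurable range: the limit of > 100000 nM in this assay, at which 2 of the 4 values shown sit.

From the compounds shown here alone, it remains open whether a benzyl group carrying an amine or a carboxylic acid instead of chlorine would give a clearly lower number.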